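This account rests on a few compounds, and the source may have more. Where it says the series, first, only, none or still open, it means among the compounds named here.

Of the compounds shown here, three built on a shared core have been tested in an assay for inhibition of serine/threonine-protein kinase Chk2 (Homo sapiens), tested at 1 uM; a lower number here means less inhibition, a higher number more inhibition at the concentration tested (going by the name of the read-out). Compound 1 `COc1ccc(S(N)(=O)=O)cc1C(=O)Nc1cccc(-c2nncn2C(C)C)n1` gives 73%. Compound 2 `COc1cc(C)c(S(N)(=O)=O)cc1C(=O)Nc1cccc(-c2nncn2C(C)C)n1` gives 87%, and compound 3 `COc1ccc(S(C)(=O)=O)cc1C(=O)Nc1cccc(-c2nncn2C(C)C)n1` gives 48%. Of these three numbers, compound 3 stands lowest; compound 1 lies nearest to it and compound 2 furthest, both separated from it by more than the usual scatter. Two single changes link the measured compounds. With methyl in place of hydrogen on an aromatic carbon, the reading was a number 14 percentage points higher from compound 1 to compound 2 (beyond the scatter). With methyl in place of amino on a sulfonyl sulfur, the reading was a number 25 percentage points lower from compound 1 to compound 3 (beyond the scatter). Compound 4 `COc1cc(C)c(S(C)(=O)=O)cc1C(=O)Nc1cccc(-c2nncn2C(C)C)n1` has not yet been measured. It differs from compound 3 in one place: methyl in place of hydrogen on an aromatic carbon. For the measured compounds named here, the only measured step that bears on this change is the one from compound 1 to compound 2, which was modest and upward, so a rise of a similar, modest size is expected for compound 4. Compound 4 is therefore estimated at 62%, within a range from 48% to 76%. The expected step is a number 14 percentage points higher from compound 3 to compound 4 (beyond the scatter).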

Compound 4, a percentage reported as inhibition, at one concentration (the size of the read-out at that concentration, not a potency): 76%
Compound 4: the middle estimate sits 14 percentage points below what was measured, and the stated range covers the measured number.
By their numbers in this assay, from the lowest: compound 3; then compounds 1 and 4 (each within the scatter of the next); then compound 2.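

On the core of compound 3, methyl in place of hydrogen on this aromatic carbon, ortho to a methylsulfonyl group, again raises the reading, giving a number 28 percentage points higher from compound 3 to compound 4 (beyond the scatter). The rise is therefore not confined to the core of compound 1, and the two steps agree in direction, with sizes that do not differ beyond the scatter: the same change on two cores in this assay, a number 14 percentage points higher (beyond the scatter) from compound 1 to compound 2 and a number 28 percentage points higher (beyond the scatter) from compound 3 to compound 4, 14 percentage points apart, within the scatter of two such steps. Methyl in place of amino on the sulfonyl sulfur also still lowers the reading when the new methyl is present, giving a number 11 percentage points lower from compound 2 to compound 4 (beyond the scatter), which matches the earlier step on the core without that methyl: the same change on two cores in this assay, a number 25 percentage points lower (beyond the scatter) from compound 1 to compound 3 and a number 11 percentage points lower (beyond the scatter) from compound 2 to compound 4, 14 percentage points apart, within the scatter of two such steps. The compounds shown leave open whether an ethyl group, a chlorine atom or an amine on this aromatic carbon would also raise the reading. They also leave open whether the rise would persist with a carboxylic acid in place of the sulfonyl group.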